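From compound 3 to compound 4: an amide group swap

The source may report more compounds than this note shows. Statements on the series, on what has been measured and on what is new or still open speak of the compounds shown alone.

Measured in a functional assay on PC-3 cells (Homo sapiens) for antiproliferative activity, read by MTT assay, with a stated time of 48 h; on this read-out higher numbers stand for weaker inhibition and lower numbers for stronger inhibition:
- Compound 1 `CCN(CC)CCNC(=O)c1ccc(C(CC)(CC)c2ccc(OCCC(O)(CC)CC)c(C)c2)n1CC`: 3350 nM
- Compound 2 `CCn1c(C(=O)Nc2cccc(C(F)(F)F)c2)ccc1C(CC)(CC)c1ccc(OCCC(O)(CC)CC)c(C)c1`: 23800 nM
- Compound 3 `CCC(C)C(NC(=O)c1ccc(C(CC)(CC)c2ccc(OCCC(O)(CC)CC)c(C)c2)n1CC)C(=O)OC`: > 50000 nM

For compound 3, this entry is a limit of the assay and not a number. Compound 3 is the weakest of the three, with both steps to it beyond the scatter: an at least 14-fold higher number from compound 1 to compound 3 (1.17 log units; beyond the scatter) and an at least 2.1-fold higher number from compound 2 to compound 3 (0.32 log units; beyond the scatter).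

Compound 4 `CCOC(=O)CN(C)C(=O)c1ccc(C(CC)(CC)c2ccc(OCCC(O)(CC)CC)c(C)c2)n1CC` has not yet been measured. Its change from compound 3 is a group of 8 heavy atoms (5 carbon, 1 nitrogen, 2 oxygen; no ring) in place of a group of 10 heavy atoms (7 carbon, 1 nitrogen, 2 oxygen; no ring), on a carbonyl carbon, and the entering group is ((ethoxycarbonyl)methyl)(methyl)amino.

Among the measured compounds shown here, no measured step makes this exact swap. The closest evidence comes from the changes on the amide-type nitrogen, where a 7.1-fold higher number from compound 1 to compound 2 (0.85 log units; beyond the scatter) is modest and the step to compound 3 is large. For the measured compounds named here, compound 4, like compound 3, lacks the 2-(diethylamino)ethyl group of compound 1, so weak activity is expected to persist in this assay, with no step clearly beyond the scatter. The expected change is an at least 1.2-fold lower number from compound 3 to compound 4 (0.09 log units; that floor lies within the scatter). The estimate for compound 4 is 40000 nM, within a range of 15000 nM to 100000 nM.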

Compound 4, half-maximal inhibitory concentration: 7140 nM
The estimate for compound 4 lay 5.6-fold (0.75 log units) above the measured number, outside the stated range (below it).
By their numbers in this assay, from the lowest: compound 1; then compound 4; then compound 2. At a limit, above all of these: compound 3.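

In this assay, placing ((ethoxycarbonyl)methyl)(methyl)amino on the carbonyl carbon gives an at least 7.0-fold lower number from compound 3 to compound 4 (0.84 log units; beyond the scatter), so a group carrying an ester at this position does not by itself push the number to the limit. This group also improves on the aryl amide, with a 3.3-fold lower number from compound 2 to compound 4 (0.52 log units; beyond the scatter), but it does not match the basic-free comparison's reference, the (2-(diethylamino)ethyl)amino group, with a 2.1-fold higher number from compound 1 to compound 4 (0.33 log units; beyond the scatter), so compound 1 keeps the lowest number while the diethylamino group proves not to be required for activity in the low micromolar-free sense shown here. The entry for compound 3 is a limit of the assay and not a number, so the first of these steps is only a bound: the limit of > 50000 nM in this assay, at which 1 of the 4 values shown sits.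

The compounds shown do not separate the loss of the amide hydrogen from the change in the rest of the group. From the compounds shown here alone, whether a carboxylic acid in place of the ethyl ester would hold the number also stays open.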